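From phenyl to 3-fluorophenyl on a shared core

The source may report more compounds than this note shows. Statements on the series, on what has been measured and on what is new or still open speak of the compounds shown alone.

In a functional assay on MCF7 cells (Homo sapiens) for antiproliferative activity, read by MTT assay, with a stated time of 72 h (on this read-out higher numbers stand for weaker inhibition and lower numbers for stronger inhibition), compound 3 (`COc1cc(-n2cnc3ccc(-c4ccccc4)cc32)cc(OC)c1OC`) gives 2290 nM as its value. On the same core, compound 1 (`CCOc1ccc(-c2ccc3ncn(-c4cc(OC)c(OC)c(OC)c4)c3c2)cc1`) gives 1710 nM and compound 2 (`COc1ccccc1-c1ccc2ncn(-c3cc(OC)c(OC)c(OC)c3)c2c1`) gives 1750 nM so that compound 3 stands within the scatter of both.

Compound 4 (`COc1cc(-n2cnc3ccc(-c4cccc(F)c4)cc32)cc(OC)c1OC`) differs from compound 3 by one change (fluoro in place of hydrogen on an aromatic carbon) in which fluoro takes the place of hydrogen on an aromatic carbon, so that phenyl becomes 3-fluorophenyl. Among the compounds with values here, no measured compound carries fluoro, which leaves only indirect evidence from other groups on the same phenyl ring. Hydrogen in place of ethoxy gives a 1.3-fold higher number from compound 1 to compound 3 (0.13 log units; within the scatter) as its step, while hydrogen in place of methoxy gives a 1.3-fold higher number from compound 2 to compound 3 (0.12 log units; within the scatter) as its step. The exchange of 4-ethoxyphenyl for 2-methoxyphenyl gives a 1.0-fold higher number from compound 1 to compound 2 (0.01 log units; within the scatter) as its step. All three steps lie within the scatter, so these three compounds show no sensitivity to such changes in this assay and no direction can be drawn from them. The expected result is a 1.1-fold lower number from compound 3 to compound 4 (0.06 log units; within the scatter) as an estimated step, with no shift beyond the scatter anticipated. In this assay compound 4 is expected to give 2000 nM as its estimated value, with 1000 nM to 4000 nM as its estimated range.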

Compound 4, half-maximal inhibitory concentration: 2350 nM
Beside the measured number, compound 4's estimate is 1.2-fold (0.07 log units) below it, within the range that was stated.
By their numbers in this assay, from the lowest: compounds 1, 2, 3 and 4 (each within the scatter of the next).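

Fluoro in place of hydrogen on the phenyl ring gives a 1.0-fold higher number from compound 3 to compound 4 (0.01 log units; within the scatter) in this assay, which is the first direct reading for a halogen on this ring and shows that a single fluorine atom, meta to a large group, leaves the number inside the scatter. Set against the two alkoxy-bearing rings, the 3-fluorophenyl group gives a 1.3-fold higher number from compound 2 to compound 4 (0.13 log units; within the scatter) and a 1.4-fold higher number from compound 1 to compound 4 (0.14 log units; within the scatter), so that the 3-fluorophenyl, 2-methoxyphenyl, 4-ethoxyphenyl and unsubstituted phenyl compounds all lie within the scatter of one another, and the flat picture that the earlier compounds suggested now extends to a halogen. Nothing available here accounts for this lack of response to the change.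

Going by these compounds, it remains open whether an amine, a carboxylic acid or a longer chain on this phenyl ring would move the number beyond the scatter, or whether these four compounds simply sample too narrow a set of groups to show any trend. The compounds shown also leave open whether fluoro at another place on the ring, or a heavier halogen such as chlorine or bromine, would behave as it does in compound 4 in this assay.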